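Amino for Methyl at the Benzylic Carbon of Compound 2

This account rests on a few compounds, and the source may have more. Where it says the series, first, only, none or still open, it means among the compounds named here.

Of the compounds shown here, three sharing a bis-amide core have been tested in an assay on isolated protein for inhibition of Rho-associated protein kinase 2 (Homo sapiens), read by scintillation counting, radiometric assay and 33P incorporation, with a stated time of 40 min, in the presence of a further agent that is not named here; on this read-out lower numbers stand for stronger inhibition and higher numbers for weaker inhibition. Compound 2 `CCc1ccc(C(=O)Nc2cccc(NC(=O)COc3ccc4c(=O)ccoc4c3)c2)cc1` gives 24 nM, the lowest number of the set. Compound 1 `COc1ccc(OCC(=O)Nc2cccc(NC(=O)c3ccc(N(C)C)cc3)c2)cc1F` gives 652 nM and compound 3 `CC(C)(C)c1ccc(S(=O)(=O)Nc2cccc(NC(=O)COc3ccc4c(=O)ccoc4c3)c2)cc1` gives 899 nM; both stand beyond the usual scatter above compound 2, so compound 2 is the most potent of the three. Compound 4 `NCc1ccc(C(=O)Nc2cccc(NC(=O)COc3ccc4c(=O)ccoc4c3)c2)cc1` has not yet been measured. It differs from compound 2 in one place: amino in place of methyl on a saturated chain carbon bound to an aromatic carbon. Going by the values given here, no measured pair shows this change, so the expectation is uncertain. The step from compound 2 to compound 4 is expected to be small, a 1.9-fold higher number from compound 2 to compound 4 (0.27 log units; within the scatter), with a slightly weaker read-out. For compound 4 the expected value in this assay is 45 nM, within a range from 8 nM to 250 nM.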

Compound 4, half-maximal inhibitory concentration: 66 nM
Compound 4: the middle estimate sits 1.5-fold (0.17 log units) below what was measured; low and high end bracket the measured number.
By their numbers in this assay, from the lowest: compound 2; then compound 4; then compounds 1 and 3 (each within the scatter of the next).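

With amino in place of methyl on a saturated chain carbon bound to an aromatic carbon, a 2.8-fold higher number from compound 2 to compound 4 (0.44 log units; beyond the scatter) stands in this assay as a modest loss that lies beyond the scatter. This position therefore accepts the change from 4-ethylphenyl to 4-(aminomethyl)phenyl with inhibition weakened but still in place. Nothing measured here gives a reason for this step. 

The compounds shown leave open how a hydroxyl, a carboxylic acid or a longer chain ending in an amine would read at this carbon. They also leave open whether the same change gives a similar step on another core.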